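Swapping a nitro group for methyl on the phenyl ring

The compounds below may be only part of what the source reports. "The series", "measured", "known", "first", "only" and "open" are said of these compounds alone.

Measured so far in a functional assay on SSMC-7721 cells (Homo sapiens) for antiproliferative activity, read by CCK-8 assay, with a stated time of 48 h; a higher number here means a weaker inhibitor, a lower number a stronger inhibitor:
compound 1 `O=c1c2ccccc2[se]n1-c1nnc(-c2ccc(Br)cc2)s1` gives 68200 nM;
compound 2 `O=c1c2ccccc2[se]n1-c1nnc(-c2cccc([N+](=O)[O-])c2)s1` gives 27300 nM;
compound 3 `Cc1ccccc1-c1nnc(-n2[se]c3ccccc3c2=O)s1` gives 19400 nM.

All three share one core and differ only in the substituent on the phenyl ring attached to it. Compound 2 stands second highest of the three numbers in this assay: its value sits close to that of compound 3, within the usual scatter, while compound 1 gives a clearly higher number.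

Compound 4 `Cc1cccc(-c2nnc(-n3[se]c4ccccc4c3=O)s2)c1` has not yet been measured. It differs from compound 2 by methyl in place of nitro on an aromatic carbon.

Among the measured compounds shown here, no measured step exchanges a nitro group for methyl directly. For the measured compounds named here, the only step among the measured compounds that bears on it is the one from compound 1 to compound 3, a 3.5-fold lower number from compound 1 to compound 3 (0.55 log units; beyond the scatter), which brings a methyl group onto the ring and lands near the value of compound 2. Since compound 3 already carries a methyl and sits close to compound 2, the change to compound 4 is expected to produce at most a small shift, likely toward a slightly lower number, but not beyond the scatter.

Compound 4 is therefore estimated at 22000 nM, within a range of 9000 nM to 55000 nM, corresponding to an expected step of a 1.2-fold lower number from compound 2 to compound 4 (0.09 log units; within the scatter).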

Compound 4, half-maximal inhibitory concentration: 17800 nM
For compound 4 the middle estimate is 1.2-fold (0.09 log units) above the measured one, and the stated range covers the measured number.
By their numbers in this assay, from the lowest: compounds 4, 3 and 2 (each within the scatter of the next); then compound 1.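

Among the compounds shown here, this is the first direct reading of nitro against methyl on an aromatic carbon, meta to a large group, and in this assay it gives a step within the scatter (a 1.5-fold lower number from compound 2 to compound 4 (0.19 log units; within the scatter)), so a group of three heavy atoms with two hydrogen-bond acceptors and a single carbon with none cannot be told apart at this place. For the compounds shown here, the placing of the methyl group cannot be told apart either: 3-methylphenyl in place of 2-methylphenyl also stays within the scatter (a 1.1-fold lower number from compound 3 to compound 4 (0.04 log units; within the scatter)), while 3-methylphenyl in place of 4-bromophenyl gives a modest step beyond it (a 3.8-fold lower number from compound 1 to compound 4 (0.58 log units; beyond the scatter)), so compound 1 remains the one compound set apart from compound 3 and compound 4. No measurement is available here that accounts for any of these numbers.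

On these data alone, whether an amine, a carboxylic acid or a longer chain at this place would also stay within the scatter remains open. Every compound shown carries the same core, so what a change to that core would do is open too.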